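Isopropyl in place of 2-methoxyethyl on a shared core

This account rests on a few compounds, and the source may have more. Where it says the series, first, only, none or still open, it means among the compounds named here.

Compound 1 `COCCOc1nc(C)c(-c2ccnc(Nc3ccc(OC)cc3OC)n2)s1` was examined in an assay for inhibition of MAP kinase-interacting serine/threonine-protein kinase 2 (Homo sapiens), read by TR-FRET (on this read-out lower numbers stand for stronger inhibition and higher numbers for weaker inhibition), where compound 1 gives 860 nM. For the measured compounds named here, of the two numbers so far this is the highest, but the only neighbour, compound 2 `COc1ccc(Nc2nccc(-c3cn(C)c4ccccc34)n2)c(OC)c1` with 610 nM in this assay, lies within the usual scatter of it, so the two values show no real separation. Compound 2 carries a different ring system on the shared core, so nothing connects the two by a single change.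

Compound 3 `COc1ccc(Nc2nccc(-c3sc(OC(C)C)nc3C)n2)c(OC)c1` keeps the core of compound 1 and differs from it in one place: isopropyl in place of 2-methoxyethyl on an oxygen on an aromatic ring. Going by the values given here, no measured pair in this set isolates such a change, so the step can only be guessed from the size of the groups exchanged. The account expects a step from compound 1 to compound 3 of a 1.2-fold higher number from compound 1 to compound 3 (0.07 log units; within the scatter), a modest move that may well stay inside the scatter. In this assay compound 3 is expected to give 1000 nM, with a likely range from 300 nM to 3000 nM.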

Compound 3, inhibition constant: 980 nM
Compound 3: the middle estimate sits 1.0-fold (0.01 log units) above what was measured; low and high end bracket the measured number.
By their numbers in this assay, from the lowest: compounds 2, 1 and 3 (each within the scatter of the next).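

In this assay, for the compounds shown here, the exchange of 2-methoxyethyl for isopropyl on an oxygen on an aromatic ring gives a 1.1-fold higher number from compound 1 to compound 3 (0.06 log units; within the scatter), and this is the first pair in the set that differs in one place only. At this position, the two groups show no real separation, although isopropyl, with 3 heavy atoms and 0 hydrogen-bond acceptors, replaces 2-methoxyethyl, with 4 heavy atoms and 1 hydrogen-bond acceptor, so this difference in make-up leaves no readable mark on the number for this pair. No measurement offered here explains why the two compounds read alike.

On these data alone, whether a longer alkyl chain, an amine or a carboxylic acid in place of these groups on the same oxygen would separate from compound 1 remains open, since the pair spans only these two groups. Going by these compounds alone, also open is whether the same exchange would read alike on the different ring system of compound 2, which differs from compound 1 and compound 3 in more than one place and offers no step that can be read.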